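4-Methylphenyl to sec-butyl on a carbonyl carbon

A few compounds are considered here, and "the series" means these few. Any claim that something is new, unique, unknown or untested is made for them only; others in the source may bear on it.

compound 1 (`CSCC(=O)N1CCN(c2nc(=O)c3cc(C(F)(F)F)cc([N+](=O)[O-])c3s2)CC1`), > 125000 nM (a limit)
compound 2 (`O=C(c1ccc(Cl)cc1)N1CCN(c2nc(=O)c3cc(C(F)(F)F)cc([N+](=O)[O-])c3s2)CC1`), > 125000 nM (a limit)
compound 3 (`Cc1ccc(C(=O)N2CCN(c3nc(=O)c4cc(C(F)(F)F)cc([N+](=O)[O-])c4s3)CC2)cc1`), > 125000 nM (a limit)

In an ADME assay on Vero cells (Chlorocebus sabaeus) for cytotoxicity, read by MTT assay, with a stated time of 72 h (a lower number here means that less compound is tolerated, a higher number that more compound is tolerated), compound 3 gives > 125000 nM as a limit of the assay, not as a number. The three measured compounds together show the limit of > 125000 nM in this assay, at which 3 of the 3 values shown sit, and nothing finer. The next case is compound 4 (`CCC(C)C(=O)N1CCN(c2nc(=O)c3cc(C(F)(F)F)cc([N+](=O)[O-])c3s2)CC1`), which carries sec-butyl in place of 4-methylphenyl on a carbonyl carbon.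

Within the data shown here, three measured steps bear on this change. Two of them replace the group on that same carbonyl carbon, a step that the two limits leave unreadable from compound 1 to compound 3 and a step that the two limits leave unreadable from compound 1 to compound 2 being the cases. The third, a step that the two limits leave unreadable from compound 2 to compound 3, swaps chloro for methyl on an aromatic carbon. None of the three has a readable size. Compound 1 carries (methylsulfanyl)methyl on the carbonyl carbon, and compound 1 gives > 125000 nM as a limit too.

For this assay no step beyond the scatter is expected, in either direction, and another limit is the likeliest report. The expected change is a number no higher from compound 3 to compound 4 (the limit leaves the size open) as estimated here. Compound 4 is estimated at 125000 nM (expected range 60000 nM to 200000 nM).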

Compound 4, half-maximal cytotoxic concentration: > 125000 nM
Compound 4 was reported as a limit; the forecaster's own chance of this, stated with the estimate: 85%; the middle value sits exactly at the limit.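

In this assay compound 4 gives > 125000 nM as a limit of the assay and not a number. Among these compounds, no step from compound 1, compound 2 or compound 3 to compound 4 can be read. The compounds shown leave open whether the groups on the carbonyl carbon differ at all in this read-out, since all of them stand at one limit: the limit of > 125000 nM in this assay, at which 4 of the 4 values shown sit.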